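An Amide Side-Chain Swap on a Weak Inhibitor

The source may report more compounds than this note shows. Statements on the series, on what has been measured and on what is new or still open speak of the compounds shown alone.

Measured so far:
Compound 1 `CN1CCC(NS(=O)(=O)c2ccccc2Nc2cc(-c3ccc4ccn(C)c4c3)c3nccnc3c2)C1`: 3160 nM
Compound 2 `Cn1cc(CNC(=O)c2ccncc2Nc2cc(-c3ccc4ccn(C)c4c3)c3nccnc3c2)cn1`: 75900 nM

In an assay on lysate for inhibition of 6-phosphofructo-2-kinase/fructose-2,6-bisphosphatase 3 (Homo sapiens), with stated times of 0.5 min and 45 min (on this read-out higher numbers stand for weaker inhibition and lower numbers for stronger inhibition), compound 2 gives 75900 nM, the higher of the two numbers shown. Compound 1 gives 3160 nM in this assay, and the gap between the two lies well beyond the usual scatter, so compound 2 is the weaker of the pair on this read-out.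

Compound 3 `Cn1ccc2ccc(-c3cc(Nc4cnccc4C(=O)NCC4COCCN4)cc4nccnc34)cc21` keeps the core of compound 2 and differs only in morpholin-3-yl in place of 1-methyl-1H-pyrazol-4-yl on a saturated chain carbon bound to an amide-type nitrogen. For the measured compounds named here, no measured pair shows this change, and nothing else here tells how it acts. The step of a 1.3-fold lower number from compound 2 to compound 3 (0.10 log units; within the scatter) is therefore expected to be small, with no clear direction and most likely within the scatter.

On this basis compound 3 is estimated to give 60000 nM in this assay, with a plausible range from 15000 nM to 200000 nM.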

Compound 3, half-maximal inhibitory concentration: 41700 nM
The estimate for compound 3 lay 1.4-fold (0.16 log units) above the measured number, within the range that was stated.
By their numbers in this assay, from the lowest: compound 1; then compounds 3 and 2 (each within the scatter of the next).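

In this assay, for the compounds shown here, the swap on the saturated chain carbon bound to the amide-type nitrogen gives a 1.8-fold lower number from compound 2 to compound 3 (0.26 log units; within the scatter), the first reading of any change at this place. Morpholin-3-yl and 1-methyl-1H-pyrazol-4-yl cannot be told apart here, even though a six-membered non-aromatic ring carrying a hydrogen-bond donor enters for a five-membered aromatic ring with none, so this difference alone does not move the number beyond the scatter. Nothing available offers an explanation for this result.

Going by these compounds, whether an open-chain amine, a carboxylic acid or a longer chain at this place would move the number beyond the scatter remains open. Also open, on these data alone, is how much of the gap to compound 1 belongs to this side chain, as compound 1 differs from these compounds in more than one place.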